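From a methoxyphenyl amide to a charged five-membered ring

The source may report more compounds than this note shows. Statements on the series, on what has been measured and on what is new or still open speak of the compounds shown alone.

Compounds measured in a functional assay on WI-38 VA13 cells (Homo sapiens) for cytotoxicity; a lower number here means that less compound is needed, a higher number that more compound is needed for the effect:
compound 1 `O=C(Nc1ccc2nc(NC(=O)C3CCCCC3)sc2c1)c1ccccc1Oc1ccccc1` gives 0.1 ug/mL
compound 2 `COc1ccc(C(=O)Nc2ccc3nc(NC(=O)C4CCCCC4)sc3c2)cc1` gives 4.9 ug/mL
compound 3 `O=C(Nc1ccc2nc(NC(=O)C3CCCCC3)sc2c1)c1ccc(Br)cc1` gives > 4 ug/mL, which is a limit of the assay and not a number.

Compound 2 holds the highest of the two numbers shown in this assay; compound 1 gives the lower one, and the gap between them lies beyond the scatter. Within the data shown here, the only step that starts from compound 2, a step that the limit leaves unreadable from compound 2 to compound 3, is left unreadable by the limit of > 4 ug/mL in this assay, at which 1 of the 3 values shown sits, so its size is not known.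

Compound 4 `Cc1[nH][n+](C)c(C)c1C(=O)Nc1ccc2nc(NC(=O)C3CCCCC3)sc2c1` differs from compound 2 as follows: a group of 8 heavy atoms (6 carbon, 2 nitrogen; one five-membered aromatic ring with 2 hetero atoms) in place of a group of 8 heavy atoms (7 carbon, 1 oxygen; one six-membered aromatic ring of carbon only), on a carbonyl carbon. Among the measured compounds shown here, no measured step swaps a group of this kind, so none of the measured steps bears directly on this change, and the one step from compound 2 gives no size to lean on. For that reason the step of a 1.0-fold higher number from compound 2 to compound 4 (0.01 log units; within the scatter) is expected to fall within the scatter in either direction, with a wide margin. Compound 4 is therefore estimated at 5 ug/mL in this assay, with a range from 1.5 ug/mL to 15 ug/mL.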

Compound 4, half-maximal effective concentration: 0.012 ug/mL
For compound 4 the middle estimate is 420-fold (2.62 log units) above the measured one; measured number below the stated range.
By their numbers in this assay, from the lowest: compound 4; then compound 1; then compound 2.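

In this assay, among these compounds, the group on this carbonyl carbon can move the number much further than the earlier compounds showed: putting the charged five-membered aromatic ring in place of 4-methoxyphenyl gives a 410-fold lower number from compound 2 to compound 4 (2.61 log units; beyond the scatter), so far less compound is needed for the effect. Compound 3 gives > 4 ug/mL, which is a limit of the assay and not a number. Even so, the change still reads as large, with an at least 330-fold lower number from compound 3 to compound 4 (2.52 log units; beyond the scatter).

Nothing shown here tells which feature of the entering ring, its charge, its hydrogen-bond donor or the ring itself, accounts for this step. Also open, on these data alone, is where a group bearing an amine or a carboxylic acid, in place of 4-methoxyphenyl on the same carbonyl carbon, would fall.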